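The compounds below may be only part of what the source reports. "The series", "measured", "known", "first", "only" and "open" are said of these compounds alone.

Compound 1 `Cn1cc([N+](=O)[O-])cc1C(=O)NNC(=S)Nc1ccccc1F`: 293000 nM
Compound 2 `Cn1cc([N+](=O)[O-])cc1C(=O)NNC(=O)Nc1ccc([N+](=O)[O-])cc1`: 402000 nM

In an ADME assay on Vero cells (Chlorocebus sabaeus) for cytotoxicity, read by MTT assay, with a stated time of 72 h (a lower number here means a stronger inhibitor, a higher number a weaker inhibitor), compound 1 and compound 2 lie within the usual scatter of each other, so the two cannot be ranked. Compound 3 `Cn1cc([N+](=O)[O-])cc1C(=O)NNC(=S)NC1CCCCC1` keeps the core of compound 1 but has cyclohexyl in place of 2-fluorophenyl on an amide-type nitrogen. Among the compounds with values here, no measured pair shows the effect of this swap, so no step beyond the scatter is expected in this assay. The expected change a 1.2-fold lower number from compound 1 to compound 3 (0.07 log units; within the scatter) is small. For compound 3, the estimate is 250000 nM, with an expected range of 100000 nM to 600000 nM.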

Compound 3, half-maximal inhibitory concentration: 352000 nM
Compound 3: middle estimate off by 1.4-fold (0.15 log units), on the low side, within the range that was stated.
By their numbers in this assay, from the lowest: compounds 1, 3 and 2 (each within the scatter of the next).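

In this assay, this swap on the amide-type nitrogen gives a 1.2-fold higher number from compound 1 to compound 3 (0.08 log units; within the scatter). Replacing the aromatic 2-fluorophenyl ring with the non-aromatic cyclohexyl ring, which also removes the fluorine, therefore leaves the number within the scatter, so these two groups cannot be told apart here. Nothing available explains this result. Still open, on these data alone, is whether a different kind of group on this nitrogen, such as an amine, a carboxylic acid or a longer chain, would move the number beyond the scatter.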